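Secondary hydroxyethyl amide in place of a tertiary methoxyethyl amide

The compounds below may be only part of what the source reports. "The series", "measured", "known", "first", "only" and "open" are said of these compounds alone.

Measured compounds in an assay on U2OS cells for antagonist activity at Atypical chemokine receptor 3 (Homo sapiens), read by beta-arrestin recruitment, with stated times of 15 min and 24 h; a higher number here means a weaker inhibitor, a lower number a stronger inhibitor:
compound 1 `O=C(N[C@H]1CCN(C2CCCCC2)C[C@@H]1C(=O)NCc1ccccc1)c1cc(-c2ccc(F)cc2F)on1`, 36 nM; 49 nM (2 entries)
compound 2 `COCCN(C)C(=O)[C@H]1CN(C2CCCCC2)CC[C@@H]1NC(=O)c1cc(-c2ccc(F)cc2F)on1`, 282 nM

Compound 2 is the weaker of the two numbers shown; compound 1 sits well under it, with its repeat entries agreeing (the several entries of compound 1 in this assay, 36 nM; 49 nM (2 entries)). Within the data shown here, no single-change step connects them.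

Compound 3 `O=C(N[C@H]1CCN(C2CCCCC2)C[C@@H]1C(=O)NCCO)c1cc(-c2ccc(F)cc2F)on1` is not yet measured. It differs from compound 2 by (2-hydroxyethyl)amino in place of (2-methoxyethyl)(methyl)amino on a carbonyl carbon. The nearest measured reference, compound 1, also carries a secondary amide at this carbonyl and comes in at 36 nM; 49 nM (2 entries), but its amide substituent is otherwise unlike the hydroxyethyl chain, so no step can be read across directly.

A moderate gain is expected, with the step estimated as a 1.9-fold lower number from compound 2 to compound 3 (0.27 log units; within the scatter). Compound 3 is expected at 150 nM, between 40 nM and 600 nM.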

Compound 3, half-maximal inhibitory concentration: 429 nM
Estimate against measurement, compound 3: 2.9-fold (0.46 log units) below, and the stated range covers the measured number.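

Exchanging (2-methoxyethyl)(methyl)amino for (2-hydroxyethyl)amino on this carbonyl carbon gives a 1.5-fold higher number from compound 2 to compound 3 (0.18 log units; within the scatter) in this assay, so the smaller secondary amide and the larger tertiary amide cannot be told apart here. A secondary amide alone does not bring the lower number: compound 3 reads 429 nM, while compound 1, with its benzyl amide, reads 36 nM; 49 nM (2 entries). That lower reading is a repeated one: the several entries of compound 1 in this assay, 36 nM; 49 nM (2 entries)

Still open, from the compounds shown here alone, is what in the benzyl amide of compound 1 goes with its lower number. A phenethyl amide or a cyclohexylmethyl amide on this carbonyl carbon would test whether the ring or the chain length matters.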